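Succinimide-bearing propanoyl phenylpiperazines in the electroshock model

The source may hold more compounds than are shown below. What is called first, only, known or untested is meant among the compounds shown, and "the series" means these compounds.

Measured compounds:
compound 1 `CC(C(=O)N1CCN(c2ccccc2)CC1)N1C(=O)CCC1=O`: 50%
compound 2 `CC(C(=O)N1CCN(c2ccc(Cl)cc2)CC1)N1C(=O)CCC1=O`: 0%
compound 3 `CCC(C(=O)N1CCN(c2ccccc2Cl)CC1)N1C(=O)CCC1=O`: 50%

In a functional assay on the whole organism (strain Swiss) with Mus musculus as the target, in the maximal electroshock model, with a stated time of 1 h, at a dose of 300 mg/kg by the intraperitoneal route (a higher number here means a stronger effect of the compound at the dose given, a lower number a weaker effect), compound 3 gives 50%, level with compound 1 at the digits shown and, together with it, the highest of the three numbers; compound 2 is the furthest away, a large step lower. Among the measured compounds shown here, the one measured step is a number 50 percentage points lower from compound 1 to compound 2 (beyond the scatter), a large drop on placing chloro in place of hydrogen on an aromatic carbon; compound 3, which also carries a chlorine on its phenyl ring, does not share this drop.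

Compound 4 `CCC(C(=O)N1CCN(c2ccc(F)cc2)CC1)N1C(=O)CCC1=O` is not yet measured. It differs from compound 3 by 4-fluorophenyl in place of 2-chlorophenyl on an amine nitrogen in a ring. For the measured compounds named here, no measured pair swaps one halogen for another or moves a halogen on the ring, so the step from compound 1 to compound 2 is the only guide, and it points downward. A fall beyond the scatter is therefore expected, but with wide uncertainty. For compound 4 the expected value in this assay is 20% (range 0% to 50%), an estimated step of a number 30 percentage points lower from compound 3 to compound 4 (beyond the scatter).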

Compound 4, a percentage reported as activity, at one dose (the size of the read-out at that dose, not a potency): 25%
Compound 4: middle estimate off by 5 percentage points, on the low side, within the range that was stated.
By their numbers in this assay, from the lowest: compound 2; then compound 4; then compounds 1 and 3 (each within the scatter of the next).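

The a number 25 percentage points lower from compound 3 to compound 4 (beyond the scatter) in this assay shows that, on the core of compound 3, the aryl group on the ring nitrogen still governs the read-out, so the earlier drop at this place is not confined to the core of compound 1. Compound 4 gives 25%, so this change weakens the effect without removing it at this dose. Nothing available bears on why the number falls here.

This change alters both the halogen and its place on the phenyl ring, so the two cannot be separated, and 2-fluorophenyl or 4-chlorophenyl on the same core would be needed to do so. From the compounds shown here alone, whether a methoxy group on the phenyl ring or a longer chain on the carbon bearing the succinimide would hold the effect remains open.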